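The source may hold more compounds than are shown below. What is called first, only, known or untested is meant among the compounds shown, and "the series" means these compounds.

Measured compounds in a functional assay on CHO cells for agonist activity at Alpha-1A adrenergic receptor (Homo sapiens), read by FLIPR and calcium flux; on this read-out higher numbers stand for larger maximal responses and lower numbers for smaller maximal responses:
- compound 1 `c1cc(-c2cn[nH]c2)c2c(c1)C(c1ncc[nH]1)CC2`: 84%
- compound 2 `CNC(=O)c1cccc2c1CCC2c1ncc[nH]1`: 59%
- compound 3 `Cn1ccc(-c2cccc3c2CCC3c2ncc[nH]2)n1`: 19%

Compound 3 stands lowest of the three; compound 2 is nearest, and compound 1 furthest above it. The two steps into compound 3 were a number 65 percentage points lower from compound 1 to compound 3 (beyond the scatter) and a number 40 percentage points lower from compound 2 to compound 3 (beyond the scatter), both beyond the scatter, so the 1-methyl-1H-pyrazol-3-yl group is linked to the weakest maximal response seen here. Compound 4 `c1cncc(-c2cccc3c2CCC3c2ncc[nH]2)c1` carries the change (pyridin-3-yl in place of 1-methyl-1H-pyrazol-3-yl on an aromatic carbon). Within the data shown here, no measured step involves pyridin-3-yl, so the direction rests only on compound 3 being the low point: a rise back toward compounds 1 and 2 is expected, but its size is uncertain. For compound 4 the expected value is 50% (range 20% to 85%), which is expected to mean a step of a number 31 percentage points higher from compound 3 to compound 4 (beyond the scatter).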

Compound 4, largest response reached (Emax), in percent of the reference or control that the assay uses: 36%
Compound 4: middle estimate off by 14 percentage points, on the high side; low and high end bracket the measured number.
By their numbers in this assay, from the lowest: compound 3; then compound 4; then compound 2; then compound 1.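

On this aromatic carbon, pyridin-3-yl in this assay gives a number 17 percentage points higher from compound 3 to compound 4 (beyond the scatter) and so recovers only part of the response. Set against the other two groups, it gives a number 23 percentage points lower from compound 2 to compound 4 (beyond the scatter) and a number 48 percentage points lower from compound 1 to compound 4 (beyond the scatter) as well. Ring size alone does not order the series, as pyridin-3-yl falls between the five-membered 1H-pyrazol-4-yl and 1-methyl-1H-pyrazol-3-yl, and nothing at hand explains this order.

Open, as far as these compounds go, is whether the methyl group or the point of ring attachment separates the two pyrazolyl groups. Also open, from the compounds shown here alone, is how a carboxylic acid or an aminomethyl group would behave on this carbon.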